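Sulfonyl substituent exchange from compound 2 to compound 4

The source may hold more compounds than are shown below. What is called first, only, known or untested is meant among the compounds shown, and "the series" means these compounds.

Measured in a functional assay on K562 cells (Homo sapiens) for inhibition, read by trypan blue exclusion, with a stated time of 72 h; a lower number here means a stronger inhibitor, a higher number a weaker inhibitor:
compound 1 `Cn1c(=O)c(S(=O)(=O)c2ccc(F)cc2F)cc2cnc(Nc3ccc4occc4c3)nc21` — 15000 nM
compound 2 `Cn1c(=O)c(S(=O)(=O)Cc2ccc(F)cc2)cc2cnc(Nc3ccc4[nH]ccc4c3)nc21` — 30000 nM
compound 3 `Cn1ccc2cc(Nc3ncc4cc(S(=O)(=O)c5ccc(F)cc5F)c(=O)n(C)c4n3)ccc21` — 750 nM

Compound 2 has the highest number of the three in this assay; compound 1 lies within the scatter of it, while compound 3 lies well beyond. Among the measured compounds shown here, the only single-place step, a 20-fold lower number from compound 1 to compound 3 (1.30 log units; beyond the scatter), concerns the group on a nitrogen on an aromatic ring, not the sulfonyl.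

Compound 4 `Cn1c(=O)c(S(=O)(=O)c2ccc(Br)cc2)cc2cnc(Nc3ccc4[nH]ccc4c3)nc21` is not yet measured. The change is 4-bromophenyl in place of 4-fluorobenzyl on a sulfonyl sulfur. For the measured compounds named here, no measured step bears on this position: compound 1 and compound 2 differ in two places at once, so their two values alone say nothing about the sulfonyl. Going by the values given here, with no precedent, no step beyond the scatter is expected in this assay, and a 1.5-fold lower number from compound 2 to compound 4 (0.18 log units; within the scatter) is the estimated step. Compound 4 is expected at 20000 nM, range 6000 nM to 60000 nM.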

Compound 4, half-maximal inhibitory concentration: 5000 nM
Estimate against measurement, compound 4: 4.0-fold (0.60 log units) above; the whole stated range lies above it.
By their numbers in this assay, from the lowest: compound 3; then compound 4; then compounds 1 and 2 (each within the scatter of the next).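

In this assay, among the compounds shown here, the sulfonyl position proves responsive: a 6.0-fold lower number from compound 2 to compound 4 (0.78 log units; beyond the scatter) is the only single-place step here, with 4-bromophenyl in place of 4-fluorobenzyl on the sulfonyl sulfur. This exchange alters both the halogen and the methylene link, so the step cannot be assigned to either one alone. Nothing measured here gives a cause for the step. Still open, from the compounds shown here alone, is whether 4-fluorophenyl or 4-bromobenzyl would separate those two changes, and how an amine or a carboxylic acid on the aromatic ring would read.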